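Removing a ring methyl from an inactive flavone-like series

A few compounds are considered here, and "the series" means these few. Any claim that something is new, unique, unknown or untested is made for them only; others in the source may bear on it.

Measured so far:
- compound 1, `CCCC/C=C\CCCCCCCCCc1cc(=O)c2c(O)cc(OCOC)c(C)c2o1` — in a functional assay on MCF7 cells (Homo sapiens) for antiproliferative activity, read by MTT assay (on this read-out higher numbers stand for weaker inhibition and lower numbers for stronger inhibition), compound 1 gives > 67200 nM
- compound 2, `CCCCCCCCCCCCCCCc1cc(=O)c2c(O)c(C)c(OCOC)c(C)c2o1` — in this assay compound 2 gives > 67200 nM
- compound 3, `CCCC/C=C\CCCCCCCCCc1cc(=O)c2c(O)c(C)c(OCOC)c(C)c2o1` — in this assay compound 3 gives > 67200 nM

Each of these three values is a limit of the assay, not a number. Compound 3 therefore stands only at a limit, and the other two values sit at the same limit, as the limit of > 67200 nM in this assay, at which 3 of the 3 values shown sit, records. The step from compound 1 to compound 3 is a step that the two limits leave unreadable from compound 1 to compound 3, and the step from compound 2 to compound 3 is a step that the two limits leave unreadable from compound 2 to compound 3; neither can be read, since both ends are limits.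

Compound 4, `CCCC/C=C\CCCCCCCCCc1cc(=O)c2c(O)c(C)c(OCOC)cc2o1`, is not yet measured. It differs from compound 3 by hydrogen in place of methyl on an aromatic carbon.

Within the data shown here, no measured step bears readably on this change: every value shown is a limit. The step from compound 1 to compound 3, which also concerns a methyl on an aromatic carbon, gives no size. Nothing therefore points to a step beyond the scatter in this assay in either direction, and the expectation is that compound 4 will again return only a limit. The estimated step is a step that the limit leaves unreadable from compound 3 to compound 4. Compound 4 is expected to show 100000 nM, within 30000 nM to 400000 nM.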

Compound 4, half-maximal inhibitory concentration: > 67200 nM
Compound 4: only a limit was reported (the forecaster's own chance of this, stated with the estimate: 85%); the middle value is on the limit's open side.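

Compound 3 and compound 4 both stand only at a limit, so the step between them cannot be read, and all the compounds shown share that limit: the limit of > 67200 nM in this assay, at which 4 of the 4 values shown sit. On these data alone, what stays open is whether hydrogen in place of methyl here changes anything in this assay, and how these four compounds rank against one another.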